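The source may hold more compounds than are shown below. What is called first, only, known or untested is meant among the compounds shown, and "the series" means these compounds.

Compounds measured in a functional assay for activation of Alpha-1A adrenergic receptor (Homo sapiens), read by calcium flux; a higher number here means that more compound is needed for the effect, a lower number that less compound is needed:

compound 1, `c1csc(-c2ccccc2NCC2=NCCN2)c1`, giving 2.24 nM
compound 2, `Cc1nc(-c2ccccc2NCC2=NCCN2)co1`, giving 324 nM
compound 3, `c1ccc(-c2ccccc2NCC2=NCCN2)nc1`, giving 6.76 nM

Compound 3 stands second highest of the three numbers in this assay: its nearest neighbour is compound 1, which sits lower by a 3.0-fold higher number from compound 1 to compound 3 (0.48 log units; beyond the scatter), and its furthest is compound 2, which sits higher by a 48-fold lower number from compound 2 to compound 3 (1.68 log units; beyond the scatter). All three compounds share the same core and differ only in the aromatic group attached to it.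

Compound 4, `c1ccc(-c2cnccn2)c(NCC2=NCCN2)c1`, has not yet been measured in this assay. It differs from compound 3 in one place: pyrazin-2-yl in place of pyridin-2-yl on an aromatic carbon. Both measured steps that change this same group bear on the question. Replacing thiophen-2-yl with pyridin-2-yl gave a 3.0-fold higher number from compound 1 to compound 3 (0.48 log units; beyond the scatter), a modest rise, whereas the five-membered 2-methyl-1,3-oxazol-4-yl carrying two hetero atoms stood far higher, as a 48-fold lower number from compound 2 to compound 3 (1.68 log units; beyond the scatter) shows. A six-membered ring with a second hetero atom therefore seems likely to move the number upward, beyond the scatter but probably short of the large step seen with compound 2. Compound 4 is thus expected to come in at about 25 nM, within a range of 7 nM to 100 nM, which corresponds to an estimated step of a 3.7-fold higher number from compound 3 to compound 4 (0.57 log units; beyond the scatter).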

Compound 4, half-maximal effective concentration: 4.57 nM
The estimate for compound 4 lay 5.5-fold (0.74 log units) above the measured number, outside the stated range (below it).
By their numbers in this assay, from the lowest: compound 1; then compounds 4 and 3 (each within the scatter of the next); then compound 2.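

In this assay, the change from pyridin-2-yl to pyrazin-2-yl on this aromatic carbon gives a 1.5-fold lower number from compound 3 to compound 4 (0.17 log units; within the scatter), so here a second ring nitrogen in the six-membered aromatic ring leaves the number unchanged within the scatter. Two hetero atoms in the group therefore do not by themselves bring a high number: the shift from 2-methyl-1,3-oxazol-4-yl to pyrazin-2-yl gives a 71-fold lower number from compound 2 to compound 4 (1.85 log units; beyond the scatter), while thiophen-2-yl still holds a modest edge, with a 2.0-fold higher number from compound 1 to compound 4 (0.31 log units; beyond the scatter). No measurement given here explains these differences.

The compounds leave open whether the high number of compound 2 goes with its methyl group or with its five-membered ring. They also leave open how a plain phenyl ring, or a pyrazin-2-yl ring carrying an amine or a carboxylic acid, would read at this position.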